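A few compounds are considered here, and "the series" means these few. Any claim that something is new, unique, unknown or untested is made for them only; others in the source may bear on it.

In an assay for binding affinity to adenosine receptor A1 (Homo sapiens) (on this read-out lower numbers stand for stronger inhibition and higher numbers for weaker inhibition), compound 3 `Cc1ccc2c(O)c(C(=O)NCCC(C)C)cnc2n1` gives > 10000 nM, which is a limit of the assay and not a number. Compound 1 `Cc1ccc2c(O)c(C(=O)NN3CCOCC3)cnc2n1` gives > 10000 nM, again a limit. Compound 2 `Cc1ccc2c(O)c(C(=O)NC3CCC(C)CC3)cnc2n1` is the one of the three measured compounds with a number, at 5600 nM. Compound 3 thus stands at the limit of > 10000 nM in this assay, at which 2 of the 3 values shown sit.

Compound 4 `COc1ccc(CNC(=O)c2cnc3nc(C)ccc3c2O)cc1` differs from compound 3 by 4-methoxyphenyl in place of isobutyl on a saturated chain carbon bound to an amide-type nitrogen. Going by the values given here, three measured steps touch the group on the amide nitrogen: an at least 1.7-fold higher number from compound 2 to compound 3 (0.25 log units; that floor lies within the scatter), a step that the two limits leave unreadable from compound 1 to compound 3, and an at least 1.7-fold lower number from compound 1 to compound 2 (0.25 log units; that floor lies within the scatter). Each of them exchanges one saturated group for another saturated group, and none of them puts an aromatic ring on that side of the amide. Together they show that the exchanges made so far at this position have moved this assay at most by amounts whose floor lies within the scatter, and two of the three values sit at the limit. Nothing among them therefore gives a direction for the step to compound 4 that could be read beyond the scatter. The account expects compound 4 to give 10000 nM, within a range from 3000 nM to 30000 nM, with a substantial chance that only a limit is reported. That estimate amounts to an expected a number no higher from compound 3 to compound 4 (the limit leaves the size open), not beyond the scatter.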

Compound 4, inhibition constant: 4370 nM
Beside the measured number, compound 4's estimate is 2.3-fold (0.36 log units) above it; the measured number falls inside the stated range.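

In this assay, 4-methoxyphenyl in place of isobutyl on a saturated chain carbon bound to an amide-type nitrogen gives an at least 2.2-fold lower number from compound 3 to compound 4 (0.35 log units; beyond the scatter), the only step at this position shown here that is printed as beyond the scatter. It is also the only step shown that brings an aromatic ring to this side of the amide, and it makes compound 4 the second compound here, after compound 2, to give a number and not a limit. Compound 3 is itself recorded only as a limit, so this step has a floor and its full size stays open: the limit of > 10000 nM in this assay, at which 2 of the 4 values shown sit.

The compounds shown leave open whether the aromatic ring alone or the methoxy group on it goes with this step, which a plain phenyl or a 4-chlorophenyl in the same place would help to separate. They also leave open how this assay responds to an amine, a carboxylic acid or a longer chain between the amide nitrogen and the ring.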